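Difluorophenyl Variant of a Sulfonamide Series at the Assay Limit

The source may hold more compounds than are shown below. What is called first, only, known or untested is meant among the compounds shown, and "the series" means these compounds.

Compound 1 `Cc1ccc(S(=O)(=O)N[C@@H](CC(=O)NC(C)(C)C)C(=O)NCCNC(=O)c2ccccc2)cc1` was examined in an ADME assay on HepG2 cells (Homo sapiens) for cytotoxicity; on this read-out lower numbers stand for an effect already at smaller amounts and higher numbers for an effect only at larger amounts of compound. In this assay compound 1 gives > 11000 nM, which is a limit of the assay rather than a number. The second measured compound, compound 2 `COc1cc(OC)cc(C(=O)NCCNC(=O)[C@H](CC(=O)NC(C)(C)C)NS(=O)(=O)c2ccc(C)cc2)c1`, carries a 3,5-dimethoxyphenyl in place of phenyl on a carbonyl carbon. In this assay compound 2 gives > 11000 nM, again only a limit. The step that the two limits leave unreadable from compound 1 to compound 2 therefore cannot be read in size or direction. Both measured values sit at the same point: the limit of > 11000 nM in this assay, at which 2 of the 2 values shown sit.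

Compound 3 `Cc1ccc(S(=O)(=O)N[C@@H](CC(=O)NC(C)(C)C)C(=O)NCCNC(=O)c2ccc(F)c(F)c2)cc1` differs from compound 1 by 3,4-difluorophenyl in place of phenyl on a carbonyl carbon. The place is a carbonyl carbon whose other neighbours are an amide-type nitrogen, so the benzoyl of compound 1 becomes a (3,4-difluorophenyl)carbonyl. No measured step bears directly on this change, and the only step between measured compounds is unreadable, so neither a direction nor a size beyond the scatter can be drawn from the numbers shown.

Compound 3 is therefore expected to give 15000 nM in this assay, within 8000 nM to 40000 nM, most probably reported again as a limit. The step that the limit leaves unreadable from compound 1 to compound 3 is thus estimated to stay within the scatter.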

Compound 3, half-maximal effective concentration: > 11000 nM
Compound 3: a limit, no number; the forecaster's own chance of this, stated with the estimate: 85%; the middle value lies beyond the limit too.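

In this assay compound 3 gives > 11000 nM, again a limit of the assay. No step among compound 1, compound 2 and compound 3 can be read in size or direction: the limit of > 11000 nM in this assay, at which 3 of the 3 values shown sit.

The compounds shown leave open whether phenyl, 3,5-dimethoxyphenyl and 3,4-difluorophenyl on a carbonyl carbon differ at all in this assay, and at what concentration any of the three compounds would show an effect.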